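This account rests on a few compounds, and the source may have more. Where it says the series, first, only, none or still open, it means among the compounds named here.

Measured so far:
- compound 1, `C[C@@H](NC(=O)Nc1cccc(C(F)(F)F)c1)c1ccccc1`: 72%
- compound 2, `CCOC(=O)c1cccc(NC(=O)N[C@H](C)c2ccccc2)c1`: 94%
- compound 3, `CCOC(=O)c1cccc(NC(=O)N[C@@H](C)c2ccccc2)c1`: 99%

All three were tested in an ADME assay on the whole organism with Oryza sativa as the target, tested at 1 uM; on this read-out higher numbers stand for a weaker effect at the one concentration tested and lower numbers for a stronger effect. Compound 2 stands second highest of the three numbers: compound 3 lies closest, a number 5 percentage points higher from compound 2 to compound 3 (within the scatter), and compound 1 lies furthest, with compound 2 giving a reading that is a number 22 percentage points higher from compound 1 to compound 2 (beyond the scatter). Because (the fact that compounds 2 and 3 differ only in the configuration as drawn), the small gap between compound 2 and compound 3 is read as noise rather than as a real difference.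

The next compound, compound 4, is `C[C@@H](NC(=O)Nc1cccc(Cl)c1)c1ccccc1`. It is reached from compound 2 by a single exchange: chloro in place of ethoxycarbonyl on an aromatic carbon. Within the data shown here, the change sits at the very place where compound 1 and compound 2 already differ, so the one measured step that bears on it is the one from compound 1 to compound 2, which was a number 22 percentage points higher from compound 1 to compound 2 (beyond the scatter). Swapping the ethoxycarbonyl for a small single-atom group is therefore expected to move the reading back downward by a modest amount, beyond the scatter but short of a large shift. For compound 4 in this assay the expected step is a number 16 percentage points lower from compound 2 to compound 4 (beyond the scatter). Compound 4 is thus estimated at 78%, within a range from 62% to 94%.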

Compound 4, a percentage reported as activity, at one concentration (the size of the read-out at that concentration, not a potency): 91%
Compound 4: middle estimate off by 13 percentage points, on the low side; the measured number falls inside the stated range.
By their numbers in this assay, from the lowest: compound 1; then compounds 4, 2 and 3 (each within the scatter of the next).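

Placed on this aromatic carbon, chloro in place of ethoxycarbonyl gives, in this assay, a number 3 percentage points lower from compound 2 to compound 4 (within the scatter), so these two groups cannot be told apart here even though chloro has 1 heavy atom and ethoxycarbonyl has 5. Chloro in place of trifluoromethyl gives a number 19 percentage points higher from compound 1 to compound 4 (beyond the scatter), which shows that among the three groups seen at this place only trifluoromethyl stands apart, and that having fewer heavy atoms than ethoxycarbonyl is not enough on its own to bring the number down to that of compound 1. Nothing in the data at hand accounts for why trifluoromethyl differs from chloro at this place.

From the compounds shown here alone, it remains open whether other groups on the same aromatic carbon, such as a nitrile, a methoxy group or an amine, would join trifluoromethyl or stay with chloro and ethoxycarbonyl. The compounds shown also leave open how a trifluoromethyl or chloro group would read on a different carbon of the ring, and whether the mirror-image form of compound 4 would give the same number.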